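The source may report more compounds than this note shows. Statements on the series, on what has been measured and on what is new or still open speak of the compounds shown alone.

In an in vivo ADME assay on the whole organism for metabolic stability, with Rattus norvegicus as the target, using cassette dosing (on this read-out higher numbers stand for a longer-lived compound and lower numbers for a shorter-lived compound), three compounds have been measured. Compound 1 `CC[C@@]1(O)C[C@H](C(=O)Nc2ccc(-n3cccc(C)c3=O)cc2F)N(C(=O)Nc2ccc(Cl)cc2)C1` gives 5.2 h in this assay. Compound 2 `CC[C@@]1(OC)C[C@H](C(=O)Nc2ccc(-n3ccccc3=O)cc2F)N(C(=O)Nc2ccc(Cl)cc2)C1` gives 1.7 h. Compound 3 `Cc1ccc([C@@]2(O)C[C@H](C(=O)Nc3ccc(-n4ccccc4=O)cn3)N(C(=O)Nc3ccc(Cl)cc3)C2)cc1` gives 1.8 h. Among these three numbers compound 3 stands second highest: its nearest neighbour is compound 2, whose number is slightly lower but within the usual scatter of the measurement, so the two cannot be told apart, while compound 1 shows a higher number, and that gap lies beyond the scatter.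

Compound 4 `O=C(Nc1ccc(-n2ccccc2=O)cn1)[C@H]1C[C@](O)(c2ccc(F)c(F)c2)CN1C(=O)Nc1ccc(Cl)cc1` has not yet been measured. It differs from compound 3 in one place: 3,4-difluorophenyl in place of 4-methylphenyl on a saturated ring carbon. The rest of the molecule is unchanged. Among the compounds with values here, no measured pair shows what such a swap does in this assay, so there is no direct basis for a step in either direction. The expected step from compound 3 to compound 4 in this assay is therefore no change at the digits printed from compound 3 to compound 4 (within the scatter), none beyond the scatter. Compound 4 is estimated at 1.8 h, with a range from 0.7 h to 4.5 h.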

Compound 4, half-life: 2.1 h
Beside the measured number, compound 4's estimate is 1.2-fold (0.07 log units) below it; the range from low to high includes it.
By their numbers in this assay, from the lowest: compounds 2, 3 and 4 (each within the scatter of the next); then compound 1.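

Swapping 4-methylphenyl for 3,4-difluorophenyl on the saturated ring carbon in this assay gives a 1.2-fold higher number from compound 3 to compound 4 (0.07 log units; within the scatter), the first step that can be read at this position. In this one pair, a methyl group leaves and two fluorine atoms enter, and the half-life does not separate the two compounds. So this position can carry either of these substituted phenyl groups with no change that can be told from the scatter, and no measured information is available to explain that outcome.

Still open, as far as these compounds go, is whether a different group on this ring carbon, such as an amine, a carboxylic acid or a longer chain, would shift the half-life beyond the scatter. Also open, from the compounds shown here alone, is whether this same swap would give a similar result on a different version of the molecule.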